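This account rests on a few compounds, and the source may have more. Where it says the series, first, only, none or still open, it means among the compounds named here.

For the measured compounds named here, in a functional assay on NAMALVA cells (Homo sapiens) for cytotoxicity, read by MTT assay, with a stated time of 72 h (on this read-out higher numbers stand for weaker inhibition and lower numbers for stronger inhibition), compound 1 (`O=C(Nc1ccc(C(=O)NO)cc1)Nc1ccc([N+](=O)[O-])cc1`) gives 13300 nM as the higher of the two numbers so far, with compound 2 (`O=C(CCc1ccc(NC(=O)Nc2ccccc2)cc1)NO`) lower at 780 nM and the gap beyond the scatter. Compound 3 (`O=C(CCc1ccc(NC(=O)Nc2ccc([N+](=O)[O-])cc2)cc1)NO`) has 2-(hydroxycarbamoyl)ethyl in place of hydroxycarbamoyl on an aromatic carbon of the core of compound 1 (2-(hydroxycarbamoyl)ethyl in place of hydroxycarbamoyl on an aromatic carbon). Compound 2 already carries 2-(hydroxycarbamoyl)ethyl and stands at 780 nM on this read-out. A large step to lower numbers, beyond the scatter, is therefore expected in this assay (estimated as a 15-fold lower number from compound 1 to compound 3 (1.17 log units; beyond the scatter)). The estimate for compound 3 is 900 nM (expected range 300 nM to 3000 nM).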

Compound 3, half-maximal inhibitory concentration: 2500 nM
Compound 3: middle estimate off by 2.8-fold (0.44 log units), on the low side; low and high end bracket the measured number.
By their numbers in this assay, from the lowest: compound 2; then compound 3; then compound 1.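

In this assay, on the nitro-bearing core, 2-(hydroxycarbamoyl)ethyl in place of hydroxycarbamoyl gives a 5.3-fold lower number from compound 1 to compound 3 (0.73 log units; beyond the scatter) and so moves the number beyond the scatter at this position. Nitro in place of hydrogen on an aromatic carbon, with that chain present, gives a 3.2-fold higher number from compound 2 to compound 3 (0.51 log units; beyond the scatter) in the opposite direction. Open, from the compounds shown here alone, is whether an amine in place of nitro keeps the number of compound 2 or compound 3, and whether a longer chain ending in hydroxycarbamoyl, or a carboxylic acid in place of hydroxycarbamoyl, shifts it further. No measurement at hand accounts for either step.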